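Bromo for nitro on the benzyl ring: working notes

The source may hold more compounds than are shown below. What is called first, only, known or untested is meant among the compounds shown, and "the series" means these compounds.

Compound 1 `Cc1cc(OCc2cn(Cc3ccc([N+](=O)[O-])cc3)nn2)ccc1Cl` and compound 2 `Cc1cc(OCc2cn(Cc3ccc(Br)cc3)nn2)ccc1Cl` share one core and differ at a single aromatic carbon: bromo in place of nitro on an aromatic carbon. In a physicochemical assay, read by spectrophotometry, with a stated time of 30 min (a higher number here means a weaker inhibitor, a lower number a stronger inhibitor), compound 1 gives 13.4 ug/mL and compound 2 gives 16.5 ug/mL; the step between them, a 1.2-fold higher number from compound 1 to compound 2 (0.09 log units; within the scatter), does not separate the two. Compound 3 `O=[N+]([O-])c1ccc(Cn2cc(COc3ccc([N+](=O)[O-])cc3I)nn2)cc1` carries a different core; how its core differs from that of compound 1 is not broken down here. In this assay compound 3 gives 16.8 ug/mL, which sits within the scatter of both compound 1 and compound 2. Compound 4 `O=[N+]([O-])c1ccc(OCc2cn(Cc3ccc(Br)cc3)nn2)c(I)c1` has not been measured. It is related to compound 3 by bromo in place of nitro on an aromatic carbon, the same change that turns compound 1 into compound 2, at a place described in the same words. For compound 4 in this assay the expected step is a 1.2-fold higher number from compound 3 to compound 4 (0.08 log units; within the scatter), a shift that rests on the step of a 1.2-fold higher number from compound 1 to compound 2 (0.09 log units; within the scatter) seen on the other core and is expected to remain within the scatter. On that basis compound 4 is estimated at 20 ug/mL, with a likely range from 12 ug/mL to 32 ug/mL.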

Compound 4, half-maximal inhibitory concentration: 18.5 ug/mL
Compound 4: middle estimate off by 1.1-fold (0.03 log units), on the high side; the range from low to high includes it.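

Notes on the new step

In this assay bromo in place of nitro on the core of compound 3 gives a 1.1-fold higher number from compound 3 to compound 4 (0.04 log units; within the scatter) and on the core of compound 1 gives a 1.2-fold higher number from compound 1 to compound 2 (0.09 log units; within the scatter) and neither pair separates, so on these two cores the change carries across as a step that stays within the scatter. This does not show that the change has a real effect of a fixed size on either core, and two steps this small cannot establish that it transfers as a defined shift rather than simply leaving the reading unresolved. No measured information bears on why the two pairs read alike.

From the compounds shown here alone, only nitro and bromo appear at this place on the benzyl ring, so the outcome with an amine, a carboxylic acid or a longer chain there remains open. Also open, going by these compounds, is whether the 4-nitrophenyl to 4-bromophenyl change would read the same way on any core beyond these two.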